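Sulfone for Thioether Under a Shifted Fluoro Pattern

The compounds below may be only part of what the source reports. "The series", "measured", "known", "first", "only" and "open" are said of these compounds alone.

Three compounds share one core carrying a fluoro group and either a methylsulfanyl or a methylsulfonyl group. In a functional assay for agonist activity at Alpha-1A adrenergic receptor (Homo sapiens) (on this read-out higher numbers stand for an effect only at larger amounts of compound and lower numbers for an effect already at smaller amounts), compound 2 `CSc1ccc(F)cc1NCC1=NCCN1` gives 2.29 nM. Compound 1 `CS(=O)(=O)c1ccc(F)cc1NCC1=NCCN1` gives 16.6 nM in this assay. The change between them, (methylsulfonyl in place of methylsulfanyl on an aromatic carbon), produced a 7.2-fold higher number from compound 2 to compound 1 (0.86 log units; beyond the scatter). Compound 3 `CSc1c(F)cccc1NCC1=NCCN1` gives 7.76 nM in this assay; how the core of compound 3 differs from that of compound 2 is not broken down here, the two having the same atoms joined differently. Compound 4 `CS(=O)(=O)c1c(F)cccc1NCC1=NCCN1` has not yet been measured in this assay. It differs from compound 3 by methylsulfonyl in place of methylsulfanyl on an aromatic carbon, the same kind of change as that between compound 2 and compound 1 but not the same: in compound 4 the entering methylsulfonyl stands ortho to a fluoro group, whereas in compound 1 it stands para to a fluoro group. The expected step is a 7.2-fold higher number from compound 3 to compound 4 (0.86 log units; beyond the scatter). Going by the values given here, this expectation rests on the one step already seen for this change, namely a 7.2-fold higher number from compound 2 to compound 1 (0.86 log units; beyond the scatter), allowing for the shifted surroundings. Compound 4 is therefore estimated at 56 nM, plausibly between 20 nM and 160 nM.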

Compound 4, half-maximal effective concentration: 24 nM
Compound 4: middle estimate off by 2.3-fold (0.37 log units), on the high side; the range from low to high includes it.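

In this assay, the second core responds in the same direction as the first, with methylsulfonyl in place of methylsulfanyl giving a 3.1-fold higher number from compound 3 to compound 4 (0.49 log units; beyond the scatter). The size of the change also carries over as far as these data can tell, since the gap between the two steps does not exceed the scatter: the same change on two cores in this assay, a 7.2-fold higher number (0.86 log units; beyond the scatter) from compound 2 to compound 1 and a 3.1-fold higher number (0.49 log units; beyond the scatter) from compound 3 to compound 4, 2.3-fold (0.37 log units) apart, within the scatter of two such steps. Going by these compounds alone, this shows that the change behaved alike on these two cores, but with only two pairs it does not establish a rule for other cores, nor does it explain why the number rises or show whether having the methylsulfonyl ortho to a fluoro group, as in compound 4, has any effect of its own.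

The compounds shown leave open how a methylsulfinyl group, a methoxy group or an amine would behave in the place of methylsulfonyl. On these data alone, all four compounds also carry a single fluoro group, so it remains unknown whether the step would hold with chloro or with hydrogen in its stead.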